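Replacing a fluorophenyl by pyridinyl in a desaturase inhibitor series

A few compounds are considered here, and "the series" means these few. Any claim that something is new, unique, unknown or untested is made for them only; others in the source may bear on it.

Measured compounds:
Compound 1 `Cc1cccc(-c2ccc(-c3nc4ccc(S(C)(=O)=O)cc4[nH]3)cc2)c1`: 319 nM
Compound 2 `CS(=O)(=O)c1ccc2nc(-c3ccc(-c4cccc(F)c4)cc3)[nH]c2c1`: 21 nM

Both compounds were tested in an assay on isolated protein for inhibition of acyl-CoA desaturase 1 (Rattus norvegicus); a lower number here means a stronger inhibitor, a higher number a weaker inhibitor. Compound 2 gives the lower of the two numbers, and the gap to compound 1 is large: a 15-fold lower number from compound 1 to compound 2 (1.18 log units; beyond the scatter). Among the measured compounds shown here, that step swapped one small substituent for another on the same six-membered aromatic ring of carbon only, and it is the only measured step in this set.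

Compound 3 `CS(=O)(=O)c1ccc2nc(-c3ccc(-c4cccnc4)cc3)[nH]c2c1` has not yet been measured. It differs from compound 2 in one place: pyridin-3-yl in place of 3-fluorophenyl on an aromatic carbon. Here the whole 3-fluorophenyl group is exchanged, not just one substituent on it, so the measured step from compound 1 to compound 2 bears on the change only loosely; it shows that this part of the molecule can shift the number a great deal, but it does not show which way a pyridin-3-yl would move it. With no closer comparison available, a moderate weakening is expected for compound 3, within the range of a 2.9-fold higher number from compound 2 to compound 3 (0.46 log units; beyond the scatter), giving an estimate of 60 nM with a range from 15 nM to 250 nM.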

Compound 3, half-maximal inhibitory concentration: 425 nM
Beside the measured number, compound 3's estimate is 7.1-fold (0.85 log units) below it, outside the stated range (above it).
By their numbers in this assay, from the lowest: compound 2; then compounds 1 and 3 (each within the scatter of the next).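

In this assay the exchange of the whole ring proves costly, with a 20-fold higher number from compound 2 to compound 3 (1.31 log units; beyond the scatter) for pyridin-3-yl in place of 3-fluorophenyl, so a nitrogen-containing ring of nearly the same size does not simply stand in for the fluorinated one at this position. The comparison with the methyl compound shows a 1.3-fold higher number from compound 1 to compound 3 (0.12 log units; within the scatter) and so does not separate pyridin-3-yl from 3-methylphenyl, which leaves compound 2 as the strongest inhibitor of the three and the only one with a clearly lower number. No measurement available here explains why the 3-fluorophenyl group stands apart from the other two groups.

The compounds shown leave open whether the loss follows the ring nitrogen that enters or the fluoro group that leaves, as both change in the same step; a plain phenyl or a 5-fluoropyridin-3-yl group would help to separate the two. On these data alone, it also remains open whether the low number is particular to fluoro or extends to other small substituents on the phenyl ring, such as chloro or methoxy.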